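This account rests on a few compounds, and the source may have more. Where it says the series, first, only, none or still open, it means among the compounds named here.

Three compounds share one core and differ only in the side chain that hangs from the nitrogen on the aromatic ring. In an assay on isolated protein for inhibition of sphingosine kinase 1 (Homo sapiens), read by mobility shift assay (a lower number here means a stronger inhibitor, a higher number a weaker inhibitor), compound 1 `CCCCCCCCc1ccc(NC(=O)[C@H](CO)NC)cc1` gives 2800 nM. Compound 2 `CCCCCCCCc1ccc(NC(=O)[C@@H](N)[C@@H](C)O)cc1` gives 650 nM, and compound 3 `CCCCCCCCc1ccc(NC(=O)[C@@H](N)[C@H](C)O)cc1` gives 1100 nM. Compound 3 therefore stands second highest of the three numbers: the step of a 2.5-fold lower number from compound 1 to compound 3 (0.41 log units; beyond the scatter) lies beyond the scatter, whereas the step of a 1.7-fold higher number from compound 2 to compound 3 (0.23 log units; within the scatter) stays within it, which fits with the fact that compounds 2 and 3 differ only in the configuration as drawn.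

Compound 4 `CCCCCCCCc1ccc(NC[C@@H](N)CO)cc1` differs from compound 3 in one place: 2-amino-3-hydroxypropyl in place of (1-amino-2-hydroxypropyl)carbonyl on a nitrogen on an aromatic ring. Among the compounds with values here, none of the measured steps bears directly on this change. The steps of a 4.3-fold lower number from compound 1 to compound 2 (0.63 log units; beyond the scatter) and a 2.5-fold lower number from compound 1 to compound 3 (0.41 log units; beyond the scatter) exchange one substituent for another on the carbonyl carbon, and the carbonyl itself is present in every measured compound. In compound 4 that carbonyl is gone, so the measured steps give no guide to the direction or the size of the step, and any expectation here rests on little. A modest move toward a higher number is estimated, a 2.3-fold higher number from compound 3 to compound 4 (0.36 log units; beyond the scatter), with wide uncertainty. The expected value for compound 4 is 2500 nM, within a range from 500 nM to 12000 nM.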

Compound 4, half-maximal inhibitory concentration: 5000 nM
Compound 4: the middle estimate sits 2.0-fold (0.30 log units) below what was measured, within the range that was stated.
By their numbers in this assay, from the lowest: compounds 2 and 3 (each within the scatter of the next); then compounds 1 and 4 (each within the scatter of the next).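

Putting 2-amino-3-hydroxypropyl in place of (1-amino-2-hydroxypropyl)carbonyl on the nitrogen is the only change shown that removes the carbonyl, and in this assay it gives a clear rise in the number from both compounds that carry this group (a 4.5-fold higher number from compound 3 to compound 4 (0.66 log units; beyond the scatter); a 7.7-fold higher number from compound 2 to compound 4 (0.89 log units; beyond the scatter)). Compound 1 goes against any simple rule that keeping the carbonyl gives a lower number, since its step to the carbonyl-free chain stays small (a 1.8-fold higher number from compound 1 to compound 4 (0.25 log units; within the scatter)), so the effect of this change depends on what else the starting side chain carries. Nothing measured here accounts for the size of these steps, and the one known structural relationship, between two compounds that both keep the carbonyl, does not touch this change.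

The change also shortens the side chain, so the loss of the carbonyl cannot yet be separated from the loss of the methyl group on the chain. A 2-amino-3-hydroxybutyl group on the same nitrogen would keep that methyl group without the carbonyl, and a carboxylic acid in place of the hydroxyl would test how much that end of the chain matters.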